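Amine size on the chain carbon: dimethyl to diethyl

The compounds below may be only part of what the source reports. "The series", "measured", "known", "first", "only" and "open" are said of these compounds alone.

Compound 3 `COc1ccccc1-c1cc(CN(C)C)ccc1Cl` holds the lower of the two reported numbers in a functional assay on HEK293 cells for agonist activity at 5-hydroxytryptamine receptor 7 (Homo sapiens), read by a luciferase reporter and beta-arrestin recruitment, with a stated time of 22 h (on this read-out lower numbers stand for smaller maximal responses and higher numbers for larger maximal responses), where compound 3 gives 43%; compound 2 `COc1ccccc1-c1cc(C2CCN(C)C2)ccc1Cl` gives 51%, and the step of a number 8 percentage points lower from compound 2 to compound 3 (within the scatter) lies within the scatter, so no order between the two can be claimed. Compound 1 `CCCN(CCC)Cc1ccc(Cl)c(-c2ccccc2OC)c1` is reported in this assay as "not active" (no number reported), with no number given. Compound 4 `CCN(CC)Cc1ccc(Cl)c(-c2ccccc2OC)c1` is the next compound to be measured, differing from compound 3 by diethylamino in place of dimethylamino on a saturated chain carbon bound to an aromatic carbon. Among the measured compounds shown here, no measured step covers this exact change; the step of a number 8 percentage points lower from compound 2 to compound 3 (within the scatter) concerns a different group and says little here. Compound 1, which carries a larger amine on the same chain carbon, is reported as "not active" (no number reported) in this assay, and this suggests that a larger amine on this carbon gives a smaller response. The expected step is therefore a number 13 percentage points lower from compound 3 to compound 4 (beyond the scatter), a moderate decrease, with wide uncertainty and a real chance that no number is returned. Compound 4 is estimated at 30% in this assay, with a range from 10% to 50%.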

Compound 4, largest response reached (Emax), in percent of the reference or control that the assay uses: "not active" (no number reported)
For compound 4 the study gives words and no number; there is nothing to compare the estimate with.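

In this assay, among the compounds shown here, compound 4 is reported as "not active" (no number reported) and so gives no number, which means no step from compound 3 can be read. No evidence bears on this result. The compounds shown leave open how the maximal response relates to amine size on this chain carbon.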